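A few compounds are considered here, and "the series" means these few. Any claim that something is new, unique, unknown or untested is made for them only; others in the source may bear on it.

Compound 1 `COc1cc(C2=NN(C(C)=O)C(c3cccc([N+](=O)[O-])c3)O2)cc(OC)c1OC` is one of two compounds tested in a functional assay on L1210 cells (Mus musculus) for antiproliferative activity, read by MTT assay, with a stated time of 72 h; a higher number here means a weaker inhibitor, a lower number a stronger inhibitor. There compound 1 gives 39000 nM, the higher of the two numbers, so it is the weaker inhibitor of the pair. Compound 2 `COc1ccc(C2OC(c3cc(OC)c(OC)c(OC)c3)=NN2C(C)=O)cc1OC(C)=O` gives 3900 nM in this assay, a gap beyond the usual scatter. Among the measured compounds shown here, no pair of measured compounds differing in a single place is available, so nothing can be read directly from steps. Compound 3 `COc1cc(OC)cc(C2OC(c3cc(OC)c(OC)c(OC)c3)=NN2C(C)=O)c1` keeps the core of compound 1 and differs at one saturated ring carbon: 3,5-dimethoxyphenyl in place of 3-nitrophenyl on a saturated ring carbon. Because compound 2 gives 3900 nM while compound 1 sits far higher, a move toward stronger inhibition is expected for compound 3, though its size is uncertain. The expected step is a 4.9-fold lower number from compound 1 to compound 3 (0.69 log units; beyond the scatter), toward a lower number. Compound 3 is estimated at 8000 nM, within a range from 2000 nM to 40000 nM.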

Compound 3, half-maximal inhibitory concentration: 5900 nM
Compound 3: the middle estimate sits 1.4-fold (0.13 log units) above what was measured; low and high end bracket the measured number.
By their numbers in this assay, from the lowest: compounds 2 and 3 (each within the scatter of the next); then compound 1.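

In this assay, putting 3,5-dimethoxyphenyl in place of 3-nitrophenyl on the saturated ring carbon gives a 6.6-fold lower number from compound 1 to compound 3 (0.82 log units; beyond the scatter). Among the compounds shown here, this is the first direct reading at this position, as the earlier compounds offered no pair differing in a single place. It shows that the aromatic group on this carbon can shift the measured antiproliferative activity while the rest of the molecule stays the same, though no measurement here gives a reason for the step.

Going by these compounds, the change removes the nitro group and adds two methoxy groups in one move, so the part each plays remains open. On these data alone, the effect of a plain phenyl, an aminophenyl or a simple ethyl chain on this carbon also remains unknown from these compounds.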